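Nitro for Bromo on the Anilino Ring of Compound 2

A few compounds are considered here, and "the series" means these few. Any claim that something is new, unique, unknown or untested is made for them only; others in the source may bear on it.

Measured so far:
compound 1, `FC(F)(F)c1ccc(CSc2nc(Nc3ccccc3Cl)c3ccccc3n2)cc1`, in a functional assay on HGC-27 cells (Homo sapiens) for cytotoxicity, read by MTT assay, with a stated time of 72 h (on this read-out higher numbers stand for weaker inhibition and lower numbers for stronger inhibition), gives > 50000 nM
compound 2, `FC(F)(F)c1ccc(CSc2nc(Nc3cccc(Br)c3)c3ccccc3n2)cc1`, in this assay gives 18300 nM

The value of compound 1 is a limit of the assay, not a number (the limit of > 50000 nM in this assay, at which 1 of the 2 values shown sits). Compound 2 therefore holds the only number shown, and the one measured step, an at least 2.7-fold lower number from compound 1 to compound 2 (0.43 log units; beyond the scatter), runs toward it.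

Compound 3, `O=[N+]([O-])c1cccc(Nc2nc(SCc3ccc(C(F)(F)F)cc3)nc3ccccc23)c1`, differs from compound 2 in one place: nitro in place of bromo on an aromatic carbon, on an aromatic carbon of a six-membered aromatic ring of carbon only, meta to a large group. Among the compounds with values here, the only measured step bears on it loosely, since it moved the halogen from one position to another and changed its identity at once, while the step to compound 3 keeps the position and exchanges the group. That step was at least modest and beyond the scatter; the present one is expected to be smaller.

For compound 3 the estimate is 12000 nM, between 4000 nM and 40000 nM, which means a step of a 1.5-fold lower number from compound 2 to compound 3 (0.18 log units; within the scatter) that is expected to lie within the scatter.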

Compound 3, half-maximal inhibitory concentration: > 50000 nM
Compound 3 gave a limit, no number; the forecaster's own chance of this, stated with the estimate: 15%; at least 4.1-fold (0.61 log units) between middle value and limit.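

Nitro in place of bromo on an aromatic carbon, meta to a large group, gave an at least 2.7-fold higher number from compound 2 to compound 3 (0.43 log units; beyond the scatter) in this assay. The earlier step changed the position and the halogen at once, whereas this one keeps the position and exchanges only the group, so it shows that the group at this place matters on its own. The result for compound 3 is a limit of the assay and not a number, as is the result for compound 1, so the step between them cannot be read, and compound 2 remains the only one of the three with a number: the limit of > 50000 nM in this assay, at which 2 of the 3 values shown sit.

The compounds shown leave open how far compound 3 lies past that limit, and therefore how large the loss on leaving bromo really is. They also leave open whether bromine itself is needed at this place or whether another group would serve as well, a question that a chloro, a methyl or an amino group on the same carbon would bear on.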